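Methoxy in Place of Hydrogen on Compound 2

The compounds below may be only part of what the source reports. "The series", "measured", "known", "first", "only" and "open" are said of these compounds alone.

In a physicochemical assay for lipophilicity, at pH 7.4 (a higher number here means a more lipophilic compound, a lower number a more polar compound), compound 2 `COc1cccc(C(=O)NCc2c(C)cc(C)[nH]c2=O)c1` gives 1.7 and compound 1 `COc1cccc(C(=O)NCc2c(C)cc(C)[nH]c2=O)c1C` gives 1.5, two values within the scatter of each other. Compound 3 `COc1cccc(C(=O)NCc2c(C)cc(C)[nH]c2=O)c1OC` differs from compound 2 in one place: methoxy in place of hydrogen on an aromatic carbon, ortho to a large group and ortho to a methoxy group. Among the compounds with values here, the only measured step at that carbon is a number 0.20 log units higher from compound 1 to compound 2 (within the scatter), hydrogen in place of methyl, so no shift beyond the scatter is expected in this assay. The expected step is a number 0.10 log units lower from compound 2 to compound 3 (within the scatter). Compound 3 is estimated at 1.6, with an expected range of 1.2 to 2.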

Compound 3, distribution coefficient: 1.7
Compound 3: middle estimate off by 0.10 log units, on the low side; measured number inside the range.
By their numbers in this assay, from the lowest: compounds 1, 2 and 3 (each within the scatter of the next).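

In this assay, this carbon now carries three groups across the compounds, and the new results show no change at the digits printed from compound 2 to compound 3 (within the scatter) and a number 0.20 log units higher from compound 1 to compound 3 (within the scatter). Hydrogen, methyl and methoxy at this carbon therefore give values that all lie within the scatter of one another, so this assay does not separate the three groups. No evidence is available that bears on this result. On these data alone, whether a carboxylic acid or an amine on this carbon would move the number beyond the scatter stays open.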